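The compounds below may be only part of what the source reports. "The series", "measured", "known", "first", "only" and "open" are said of these compounds alone.

In a functional assay with Oryctolagus cuniculus as the target (on this read-out lower numbers stand for stronger inhibition and higher numbers for weaker inhibition), compound 1 (`COc1ccc(-c2nc(CNC(=O)CSc3ccccc3)sc2-c2ccc(OC)cc2)cc1`) gives < 100 nM, which is a limit of the assay and not a number. Compound 2 (`COc1ccc(-c2nc(CNC(=O)CSC)sc2-c2ccc(OC)cc2)cc1`) gives < 100 nM, again a limit rather than a measured value, so its true position is not known exactly. The next structure, compound 3 (`COc1ccc(-c2nc(CNC(=O)N3CCOCC3)sc2-c2ccc(OC)cc2)cc1`), is reached by one change at the end of the side chain: morpholin-4-yl in place of (methylsulfanyl)methyl on a carbonyl carbon. In words, morpholin-4-yl stands in place of (methylsulfanyl)methyl on a carbonyl carbon, which brings in a six-membered non-aromatic ring.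

The measured data offer little guidance for this change. Going by the values given here, the only measured step, a step that the two limits leave unreadable from compound 1 to compound 2, concerns a different group and gives no size to carry over. The remaining evidence is the limit of < 100 nM in this assay, at which 2 of the 2 values shown sit, and it suggests only that this series may reach that limit. No direction can be expected because a step that the two limits leave unreadable from compound 1 to compound 2 has no readable size. The expected step, a step that the limit leaves unreadable from compound 2 to compound 3, is therefore a loose estimate, with no real change beyond the scatter forecast. For compound 3 the estimated value is 50 nM, with an expected range from 8 nM to 300 nM.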

Compound 3, half-maximal inhibitory concentration: 660 nM
Compound 3: middle estimate off by 13-fold (1.12 log units), on the low side, and the stated range ends below it.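

In this assay the group on this carbonyl carbon turns out to matter, which the two earlier compounds could not show: morpholin-4-yl in place of (methylsulfanyl)methyl gives an at least 6.6-fold higher number from compound 2 to compound 3 (0.81 log units; beyond the scatter), which means weaker inhibition. The phenyl-bearing partner gives the same picture, with morpholin-4-yl in place of (phenylsulfanyl)methyl giving an at least 6.6-fold higher number from compound 1 to compound 3 (0.81 log units; beyond the scatter), so the weakening holds against both sulfur-bearing groups. On these data alone, compound 1 and compound 2 each stand at a limit of the assay and not at a number, so the step between them cannot be read and the true size of both new steps stays unknown: the limit of < 100 nM in this assay, at which 2 of the 3 values shown sit.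

The compounds shown leave open which part of the change goes with the weaker inhibition, as morpholin-4-yl differs from both sulfur-bearing groups at once in its ring, its nitrogen on the carbonyl carbon and its oxygen. A piperidin-1-yl group, which keeps the ring but has no oxygen, or an open-chain diethylamino group, which keeps the nitrogen but has no ring, would help to pull these parts apart.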